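A few compounds are considered here, and "the series" means these few. Any claim that something is new, unique, unknown or untested is made for them only; others in the source may bear on it.

Measured in a functional assay on HCT-116 cells (Homo sapiens) for inhibition, read by colorimetric assay, with a stated time of 3 days; a lower number here means a stronger inhibitor, a higher number a weaker inhibitor:
- compound 1 `NC(=O)C(=O)NCCCCCCCC(=O)Nc1ccccc1` gives > 100000 nM (a limit of the assay)
- compound 2 `O=C(CCCCCCNC(=O)C(O)(O)C(F)(F)F)Nc1ccccc1` gives 9140 nM
- compound 3 `O=C(CCCCCCNC(=O)C(O)(O)C(F)(F)F)Nc1ccc(S(F)(F)(F)(F)F)cc1` gives 9110 nM

Going by the values given here, compound 2 holds one of only two true numbers in the set, and the other lies within the scatter of it (a 1.0-fold lower number from compound 2 to compound 3 (0.00 log units; within the scatter)). The third entry is a limit (the limit of > 100000 nM in this assay, at which 1 of the 3 values shown sits).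

Compound 4 `CC(=O)C(=O)NCCCCCCC(=O)Nc1ccccc1` carries acetyl in place of 2,2,2-trifluoro-1,1-dihydroxyethyl on a carbonyl carbon. Among the compounds with values here, the only measured step (a 1.0-fold lower number from compound 2 to compound 3 (0.00 log units; within the scatter)) lies on an aromatic carbon, so it gives no direct size for a change at this carbonyl carbon. The nearest guide is compound 1, which also lacks the 2,2,2-trifluoro-1,1-dihydroxyethyl group but differs from compound 2 elsewhere too. Compound 1 gives > 100000 nM as a limit. On that single comparison, with compound 1 at (> 100000 nM), compound 4 is expected to be a weaker inhibitor than compound 2 in this assay, with a real chance of reaching the limit. The expected change is a 4.9-fold higher number from compound 2 to compound 4 (0.69 log units; beyond the scatter) and is only loosely estimated. The estimate for compound 4 is 45000 nM within an expected range from 15000 nM to 100000 nM.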

Compound 4, half-maximal inhibitory concentration: > 100000 nM
Compound 4: no number, only a limit (the forecaster's own chance of this, stated with the estimate: 35%); middle value at least 2.2-fold (0.34 log units) away from the limit.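

At the carbonyl carbon whose other neighbour is the amide-type nitrogen, acetyl in place of 2,2,2-trifluoro-1,1-dihydroxyethyl gives, in this assay, an at least 10-fold higher number from compound 2 to compound 4 (1.03 log units; beyond the scatter), so this position responds strongly, whereas the change on the aromatic carbon gave a 1.0-fold lower number from compound 2 to compound 3 (0.00 log units; within the scatter). Among the four compounds, only compound 2 and compound 3 give true numbers, and both carry 2,2,2-trifluoro-1,1-dihydroxyethyl, so this group is tied to measurable inhibition in the series shown, with no compound going against that. The step between compound 1 and compound 4 cannot be read, since both values are limits and not numbers: the limit of > 100000 nM in this assay, at which 2 of the 4 values shown sit.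

On these data alone, the true size of the loss remains open, as does which part of the departing group matters, since the step removes the fluorine and hydroxyl atoms together. A hydroxamic acid or a carboxylic acid at this carbonyl carbon, or a trifluoromethyl ketone held apart from its hydrated form, would help to show whether the readable inhibition depends on 2,2,2-trifluoro-1,1-dihydroxyethyl itself or extends to other groups at this position.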